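A few compounds are considered here, and "the series" means these few. Any claim that something is new, unique, unknown or untested is made for them only; others in the source may bear on it.

Of the compounds shown here, two built on a shared core have been tested so far. In a functional assay on HL-60 cells (Homo sapiens) for cytotoxicity, read by luminescence and CellTiter-Glo, with a stated time of 3 days (a lower number here means a stronger inhibitor, a higher number a weaker inhibitor), compound 2 `N#Cc1ccc(NC(=O)c2ccc3cccnc3c2O)cc1` gives 370 nM and compound 1 `O=C(Nc1ccc(Cl)cc1Cl)c1ccc2cccnc2c1O` gives 610 nM. These two values lie within the scatter of each other, so the numbers do not separate the compounds. Compound 3 `N#Cc1ccc(NC(=O)c2ccc3cccnc3c2O)c(Cl)c1` is made from compound 2 by one change, with chloro in place of hydrogen on an aromatic carbon. The new chloro sits ortho to a large group and meta to a cyano group. Going by the values given here, no two measured compounds differ in only one place, so the data hold no direct measure of this change. Compound 1 also carries chloro and gives 610 nM, which offers only indirect support for expecting no large shift in this assay. The expected step, a 1.2-fold lower number from compound 2 to compound 3 (0.09 log units; within the scatter), is estimated to stay within the scatter, with no firm direction. For compound 3 the estimated value is 300 nM, with an expected range from 110 nM to 800 nM.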

Compound 3, half-maximal inhibitory concentration: 910 nM
The estimate for compound 3 lay 3.0-fold (0.48 log units) below the measured number, outside the stated range (above it).
By their numbers in this assay, from the lowest: compounds 2, 1 and 3 (each within the scatter of the next, the first and the last beyond it).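

The first direct measure of this change comes from this assay, where chloro in place of hydrogen, on the aromatic carbon ortho to a large group, gives a 2.5-fold higher number from compound 2 to compound 3 (0.39 log units; beyond the scatter) and so a modest step beyond the scatter, with a cyano group held meta to the new chloro. With chloro present at this position, cyano in place of chloro on an aromatic carbon gives a 1.5-fold higher number from compound 1 to compound 3 (0.17 log units; within the scatter) and so stays within the scatter, which means the numbers do not separate these two groups when that chloro is in place. Nothing among the data explains why the chloro raises the number from compound 2 to compound 3.

The compounds shown cover only hydrogen and chloro at this position, so it remains open whether a fluoro, a methyl or a methoxy there would give a similar step, or none. On these data alone, the chloro step has also been read only with the cyano group in place, so it remains open whether it would recur with an amine or a carboxylic acid at that other aromatic carbon.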